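The compounds below may be only part of what the source reports. "The series", "measured", "known", "first", "only" and "open" are said of these compounds alone.

Measured in a functional assay on A-375 cells (Homo sapiens) for cytotoxicity, read by MTT assay, with a stated time of 72 h, tested at 1 uM; a lower number here means less inhibition of growth, a higher number more inhibition of growth at the concentration tested:
compound 1 `Cc1cccc(/C(N)=N/NC(=S)N2CCN(c3ccccn3)CC2)n1` — 58.4%
compound 2 `N/C(=N\NC(=S)N1CCCCCC1)c1ccccn1` — 67%
compound 3 `Cc1ccnc(/C(N)=N/NC(=S)N2CCCCCC2)c1` — 61.9%

Compound 2 holds the highest of the three numbers, but neither neighbour is clearly apart from it: the gap to compound 3 is a number 5.1 percentage points lower from compound 2 to compound 3 (within the scatter) and lies within the scatter, and the number for compound 1 sits only a little further off, also within the scatter. For the measured compounds named here, no compound of this set can therefore be called the most or least active.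

Compound 4 `Cc1cccc(/C(N)=N/NC(=S)N2CCCCCC2)n1` differs from compound 2 by methyl in place of hydrogen on an aromatic carbon. Two measured compounds bear on this change. The step from compound 2 to compound 3 puts a methyl on the same ring, at another carbon, and is a number 5.1 percentage points lower from compound 2 to compound 3 (within the scatter), within the scatter. Compound 1 carries the methyl at the same position as compound 4 does, next to the ring nitrogen, with a different amine portion, and its value also lies within the scatter of compound 2. On this basis the change is expected to move this assay by no more than the scatter, with a step from compound 2 to compound 4 of about a number 4 percentage points lower from compound 2 to compound 4 (within the scatter) expected. Compound 4 is thus estimated at 63%, in the range 50% to 76%.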

Compound 4, percent growth inhibition at one concentration: 39.6%
For compound 4 the middle estimate is 23.4 percentage points above the measured one; measured number below the stated range.
By their numbers in this assay, from the lowest: compound 4; then compounds 1, 3 and 2 (each within the scatter of the next).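

In this assay, methyl next to the ring nitrogen gives a step beyond the scatter, a number 27.4 percentage points lower from compound 2 to compound 4 (beyond the scatter), while methyl at another carbon of the same ring gives only a number 5.1 percentage points lower from compound 2 to compound 3 (within the scatter). With this amine portion, the outcome therefore depends on where the methyl sits on the ring and not merely on its presence. Compound 1 has the methyl at the same position with a different amine portion and reads 58.4%, while compound 4 reads 39.6%, so the methyl at this position does not bring the lower number with every amine portion.

No measurement at hand accounts for the step from hydrogen to methyl at this position. On these data alone, whether an ethyl, a methoxy or an amine at this position would give a number nearer to that of compound 4 or to that of compound 2 remains open.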